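Turning one stereocentre in a potent ring

This account rests on a few compounds, and the source may have more. Where it says the series, first, only, none or still open, it means among the compounds named here.

Three compounds share a core in which a ring bearing a methoxyphenyl group carries a saturated oxygen-containing ring on one side and an aromatic ring on the other. Compound 2 `COc1ccccc1-n1nc([C@H]2C[C@@H](C)O[C@@H](C)C2)cc1-c1ccc(Cl)cc1` is the strongest of the three in an assay on HEK293 cells for inhibition of Voltage-dependent N-type calcium channel subunit alpha-1B (Homo sapiens), read by patch clamp, using a membrane potential dye (on this read-out higher numbers stand for weaker inhibition and lower numbers for stronger inhibition), giving 12 nM. Compound 1 `COc1ccccc1-n1nc(C2CC(C)(C)OC(C)(C)C2)cc1-c1ccnc(Cl)c1` gives 250 nM, and compound 3 `COc1ccccc1-n1nc(C2CC(C)(C)OC(C)(C)C2)cc1-c1ccc(C)nc1` gives 13000 nM. Within the data shown here, the one measured step, a 52-fold higher number from compound 1 to compound 3 (1.72 log units; beyond the scatter), concerns a swap of the aromatic ring, not the saturated ring.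

Compound 4 `COc1ccccc1-n1nc(C2C[C@H](C)O[C@@H](C)C2)cc1-c1ccc(Cl)cc1` keeps every atom and bond of compound 2; the change is the two compounds have the same atoms and bonds; at least one stereo element is drawn with a configuration in one of them and without one in the other: 2 of 3 stereo elements differ; a stereocentre at a saturated ring carbon is drawn r in compound 2 and without a configuration in compound 4; a stereocentre at a saturated ring carbon is drawn R in compound 2 and S in compound 4. Among the measured compounds shown here, no measured step touches the stereochemistry of the saturated ring, so the effect of such a change is unknown here; compounds 1 and 3 carry no defined stereocentres at all. A stereochemical change of this kind is expected to shift the number upward by a 4.2-fold higher number from compound 2 to compound 4 (0.62 log units; beyond the scatter), with wide uncertainty. Compound 4 is therefore estimated at 50 nM, in a range from 10 nM to 400 nM.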

Compound 4, half-maximal inhibitory concentration: 61000 nM
Beside the measured number, compound 4's estimate is 1200-fold (3.09 log units) below it; measured number outside the range, above it.
By their numbers in this assay, from the lowest: compound 2; then compound 1; then compound 3; then compound 4.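

The saturated ring is not a passive part of these molecules: with the atoms and bonds unchanged, a difference in drawn stereochemistry alone comes with a 5100-fold higher number from compound 2 to compound 4 (3.71 log units; beyond the scatter) in this assay. Among these compounds, the earlier measured step, a 52-fold higher number from compound 1 to compound 3 (1.72 log units; beyond the scatter), showed only that the aromatic ring matters, whereas this one shows that the three-dimensional arrangement of the saturated ring matters as well. This cannot be read as a clean swap of one stereocentre for its mirror arrangement, and the limit on that reading is this: the fact that one of compounds 2 and 4 is drawn with a defined configuration and the other without, at the place where they differ.

The compounds shown leave open which of the two differing stereocentres carries the change. They also leave open how the activity of compound 2 would respond to an ethyl group or a hydroxyl group in place of a methyl group on the saturated ring.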